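Swapping Methoxy for Bromo in a Pair at the Limit

The source may report more compounds than this note shows. Statements on the series, on what has been measured and on what is new or still open speak of the compounds shown alone.

Compound 1 `Cc1ccc(S(=O)(=O)c2nc3ccccc3nc2N2CCCC2)cc1` returns only a limit in a functional assay on PC-3 cells (Homo sapiens) for cytotoxicity, read by MTT assay, with a stated time of 72 h (a higher number here means a weaker inhibitor, a lower number a stronger inhibitor), namely > 50000 nM. Compound 2 `COc1ccc(S(=O)(=O)c2nc3ccccc3nc2N2CCCC2)cc1` likewise returns only a limit in this assay, namely > 50000 nM. The step that the two limits leave unreadable from compound 1 to compound 2 therefore cannot be read, because of the limit of > 50000 nM in this assay, at which 2 of the 2 values shown sit. Compound 3 `O=S(=O)(c1ccc(Br)cc1)c1nc2ccccc2nc1N1CCCC1` differs from compound 2 by bromo in place of methoxy on an aromatic carbon. For the measured compounds named here, the single measured step bears on this change, but its size is unreadable, so no direction beyond the scatter can be set for compound 3. Compound 3 is expected to give about 60000 nM, between 20000 nM and 200000 nM, most probably again only as a limit. The expected step is a step that the limit leaves unreadable from compound 2 to compound 3.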

Compound 3, half-maximal inhibitory concentration: > 50000 nM
Compound 3 gave a limit, no number (the forecaster's own chance of this, stated with the estimate: 75%); the middle value lies beyond the limit too.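

For the compounds shown here, no step to compound 3 from compound 1 or compound 2 can be read, since all three compounds give only a limit: the limit of > 50000 nM in this assay, at which 3 of the 3 values shown sit. The compounds shown leave open whether methyl, methoxy or bromo changes the read-out in this assay.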